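Moving the Chlorine on the Chlorophenyl Group

This account rests on a few compounds, and the source may have more. Where it says the series, first, only, none or still open, it means among the compounds named here.

Compound 2 `O=S(=O)(c1ccccc1Cl)n1ccc2c(N3CCNCC3)cccc21` was tested in an assay on HeLa cells for displacement of a labelled ligand from 5-hydroxytryptamine receptor 6 (Homo sapiens) (on this read-out higher numbers stand for weaker inhibition and lower numbers for stronger inhibition), where compound 2 gives 0.398 nM. Among the three measured compounds this is the second highest number: compound 3 `O=S(=O)(c1cccc(Cl)c1)n1ccc2c(N3CCNCC3)cccc21` gives 0.251 nM, and compound 1 `Cc1c(S(=O)(=O)n2ccc3c(N4CCNCC4)cccc32)sc2ccc(Cl)cc12` gives 3.16 nM, a much higher number. Compound 4 `O=S(=O)(c1ccc(Cl)cc1)n1ccc2c(N3CCNCC3)cccc21` differs from compound 2 in one place: 4-chlorophenyl in place of 2-chlorophenyl on a sulfonyl sulfur. Among the compounds with values here, the only measured step of the same kind, moving the chlorine on the chlorophenyl group, is a 1.6-fold lower number from compound 2 to compound 3 (0.20 log units; within the scatter), a shift too small to count as a real change. Because a 1.6-fold lower number from compound 2 to compound 3 (0.20 log units; within the scatter) barely moved the number, the expected step is a 1.2-fold lower number from compound 2 to compound 4 (0.09 log units; within the scatter), nothing beyond the scatter. Compound 4 is therefore estimated at 0.32 nM, within a range from 0.1 nM to 1 nM.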

Compound 4, inhibition constant: 2 nM
Beside the measured number, compound 4's estimate is 6.3-fold (0.80 log units) below it, and the stated range ends below it.
By their numbers in this assay, from the lowest: compounds 3 and 2 (each within the scatter of the next); then compounds 4 and 1 (each within the scatter of the next).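

The steps of a 5.0-fold higher number from compound 2 to compound 4 (0.70 log units; beyond the scatter) and an 8.0-fold higher number from compound 3 to compound 4 (0.90 log units; beyond the scatter) show that where the chlorine sits on this chlorophenyl group can matter in this assay. The earlier compounds did not show this, as compound 2 and compound 3 lie within the scatter of each other, leaving the 4-chlorophenyl group alone in standing apart among these three isomers. As far as these compounds go, whether a 4-fluorophenyl or 4-methoxyphenyl group on the sulfonyl sulfur would fall with compound 4 or with compounds 2 and 3 stays open. No measurement here explains the difference.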